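A few compounds are considered here, and "the series" means these few. Any claim that something is new, unique, unknown or untested is made for them only; others in the source may bear on it.

Compound 1 `Oc1ccc(-c2cc(-c3ccccc3C(F)(F)F)cc(-c3ccccc3O)n2)cc1` and compound 3 `Oc1cccc(-c2cc(-c3ccccc3C(F)(F)F)cc(-c3cccc(O)c3)n2)c1` both carry a 2-(trifluoromethyl)phenyl group on their cores; the difference between the two cores is not broken down here. In a functional assay on T47D cells (Homo sapiens) for inhibition (a lower number here means a stronger inhibitor, a higher number a weaker inhibitor), compound 1 gives 7180 nM. In this assay compound 3 gives 4350 nM, a number within the scatter of compound 1. Compound 2 `Oc1ccc(-c2cc(-c3cccc(C(F)(F)F)c3)cc(-c3ccccc3O)n2)cc1` differs from compound 1 by 3-(trifluoromethyl)phenyl in place of 2-(trifluoromethyl)phenyl on an aromatic carbon. For compound 2 this assay reports only a limit, > 50000 nM. The step of an at least 6.9-fold higher number from compound 1 to compound 2 (0.84 log units; beyond the scatter) rests on the limit of > 50000 nM in this assay, at which 1 of the 3 values shown sits, and reads as at least modest. Compound 4 `Oc1cccc(-c2cc(-c3cccc(C(F)(F)F)c3)cc(-c3cccc(O)c3)n2)c1` is still to be measured in this assay; it differs from compound 3 by 3-(trifluoromethyl)phenyl in place of 2-(trifluoromethyl)phenyl on an aromatic carbon. This is the same kind of change as from compound 1 to compound 2, but the surroundings differ: here the place is meta to two 3-hydroxyphenyl groups, whereas before it was meta to a 2-hydroxyphenyl group and meta to a 4-hydroxyphenyl group. Among the measured compounds shown here, the step of a 6.9-fold higher number from compound 3 to compound 4 (0.84 log units; beyond the scatter) is expected to be a weakening of similar size because an at least 6.9-fold higher number from compound 1 to compound 2 (0.84 log units; beyond the scatter) ran to a limit in the only measured instance of this change. Compound 4 is therefore estimated at 30000 nM, between 10000 nM and 100000 nM, with a real chance that only a limit is reported.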

Compound 4, half-maximal inhibitory concentration: 4970 nM
Compound 4: the middle estimate sits 6.0-fold (0.78 log units) above what was measured; measured number outside the range, below it.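

Moving the trifluoromethyl group from 2-(trifluoromethyl)phenyl to 3-(trifluoromethyl)phenyl does not have the same effect on both cores in this assay: the same change on two cores in this assay, an at least 6.9-fold higher number (0.84 log units; beyond the scatter) from compound 1 to compound 2 and a 1.1-fold higher number (0.06 log units; within the scatter) from compound 3 to compound 4, at least 6.0-fold (0.78 log units) apart, beyond the scatter of two such steps On the core with two 3-hydroxyphenyl groups, the change gives a 1.1-fold higher number from compound 3 to compound 4 (0.06 log units; within the scatter), so the loss seen on the core of compound 1 cannot be assumed to carry over to another core in this series. With one pair per core, the data show that the outcome depends on the core, but not which of the hydroxyphenyl groups decides it or why, and the earlier step has no upper bound, as compound 2 has only a limit: the limit of > 50000 nM in this assay, at which 1 of the 4 values shown sits.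

On these data alone, it remains open how the same change behaves on cores with other arrangements of the hydroxyphenyl groups. As far as these compounds go, it is also open whether an amine in place of a hydroxyl group, or a carboxylic acid in place of the trifluoromethyl group, would show the same dependence on the core.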